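From Oxadiazole to Carbamoyl on a Piperidine Urea

The source may report more compounds than this note shows. Statements on the series, on what has been measured and on what is new or still open speak of the compounds shown alone.

Measured so far:
- Compound 2 `Cc1noc(-c2cccc(NC(=O)N3CCC(Oc4ccccc4Cl)CC3)c2)n1`: in an assay on isolated protein for inhibition of acyl-CoA desaturase 1 (Mus musculus) (on this read-out higher numbers stand for weaker inhibition and lower numbers for stronger inhibition), compound 2 gives 8 nM.
- Compound 1 `CNC(=O)c1cccc(NC(=O)N2CCC(Oc3c(F)cccc3Cl)CC2)c1`: in this assay compound 1 gives 330 nM.

Of the two numbers shown, compound 2 stands lowest; compound 1 sits far higher, a gap well beyond the usual scatter of repeated measurements. For the measured compounds named here, compound 1 and compound 2 differ in more than one place, so no single step between measured compounds is available here.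

Compound 3 `NC(=O)c1cccc(NC(=O)N2CCC(Oc3ccccc3Cl)CC2)c1` keeps the shared core of compound 2 and differs from it in one place: carbamoyl in place of 3-methyl-1,2,4-oxadiazol-5-yl on an aromatic carbon. Going by the values given here, nothing measured so far isolates this exact change. Among the compounds with values here, the only other amide-bearing compound, compound 1, gives 330 nM in this assay, a much higher number than compound 2, though it also carries a second difference. On that thin basis a loss of potency is expected, probably a clear one rather than none, but smaller than the whole gap to compound 1.

Compound 3 is therefore expected to give about 100 nM in this assay, most likely between 20 nM and 500 nM, an expected step of a 13-fold higher number from compound 2 to compound 3 (1.10 log units; beyond the scatter).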

Compound 3, half-maximal inhibitory concentration: 10 nM
Estimate against measurement, compound 3: 10-fold (1.00 log units) above; measured number outside the range, below it.
By their numbers in this assay, from the lowest: compounds 2 and 3 (each within the scatter of the next); then compound 1.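

In this assay, replacing the ring with the open amide gives a 1.3-fold higher number from compound 2 to compound 3 (0.10 log units; within the scatter) at this position, an aromatic carbon meta to a large group. A low number here therefore does not depend on keeping 3-methyl-1,2,4-oxadiazol-5-yl, since carbamoyl gives a value within the usual scatter of the ring compound even though it has 3 heavy atoms in place of 6, no ring, and 1 hydrogen-bond donor where the oxadiazole has 0. No measurement shown here accounts for why two such different groups give matching numbers.

On these data alone, what remains open is how much freedom this position allows, as a carboxylic acid, a nitrile or an aminomethyl group in the same place could show whether other small groups also give low numbers or whether carbamoyl and the oxadiazole are special cases. It is also unknown what a single methyl group on the amide nitrogen would do by itself on the core of compound 3, as compound 1 carries that methyl group together with a fluorine on the other aromatic ring.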